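The source may report more compounds than this note shows. Statements on the series, on what has been measured and on what is new or still open speak of the compounds shown alone.

Measured in a functional assay on HCC1806 cells (Homo sapiens) for inhibition, read by sulforhodamine B assay, tested at 10 uM; a higher number here means more inhibition at the concentration tested (going by the name of the read-out), a lower number less inhibition:
compound 1, `CN1CCN(c2ccc(C3=NNC(c4ccc(N(C)C)cc4)C3)cc2)CC1`, gives 31.2%
compound 2, `CN1CCN(c2ccc(C3=NN(C(=O)CCCl)C(c4ccc(N(C)C)cc4)C3)cc2)CC1`, gives 1.7%
compound 3, `CN1CCN(c2ccc(C3=NN(S(=O)(=O)c4ccc(C#N)cc4)C(c4ccc(N(C)C)cc4)C3)cc2)CC1`, gives 99.8%

Compound 2 stands lowest of the three, with compound 1 above it by a number 29.5 percentage points lower from compound 1 to compound 2 (beyond the scatter) read in reverse and compound 3 above it by a number 98.1 percentage points higher from compound 2 to compound 3 (beyond the scatter). Compound 4, `CN(C)c1ccc(C2CC(c3ccc(-n4ccnc4)cc3)=NN2C(=O)CCCl)cc1`, differs from compound 2 by 1H-imidazol-1-yl in place of 4-methylpiperazin-1-yl on an aromatic carbon. Every measured step (a number 29.5 percentage points lower from compound 1 to compound 2 (beyond the scatter), a number 68.6 percentage points higher from compound 1 to compound 3 (beyond the scatter), a number 98.1 percentage points higher from compound 2 to compound 3 (beyond the scatter)) changes the group on the ring nitrogen, so none bears on this exchange at the six-membered aromatic ring; nothing here tells which way it moves. Compound 4 is therefore expected near compound 2, at 6% (range 0% to 30%), a step of a number 4.3 percentage points higher from compound 2 to compound 4 (within the scatter) expected to stay within the scatter.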

Compound 4, a percentage reported as inhibition, at one concentration (the size of the read-out at that concentration, not a potency): -5.2%
The estimate for compound 4 lay 11.2 percentage points above the measured number; measured number below the stated range.
By their numbers in this assay, from the lowest: compounds 4 and 2 (each within the scatter of the next); then compound 1; then compound 3.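

In this assay, the exchange of 4-methylpiperazin-1-yl for 1H-imidazol-1-yl on the six-membered aromatic ring gives a number 6.9 percentage points lower from compound 2 to compound 4 (within the scatter). Going by these compounds alone, this is the first reading at this position, and with (2-chloroethyl)carbonyl on the ring nitrogen the two groups cannot be told apart. No evidence bears on this result. From the compounds shown here alone, it remains open whether 1H-imidazol-1-yl would also match 4-methylpiperazin-1-yl with (4-cyanophenyl)sulfonyl on the ring nitrogen. Also open, going by these compounds, is how a morpholin-4-yl group or a plain dimethylamino group would read at this position.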